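The source may hold more compounds than are shown below. What is called first, only, known or untested is meant among the compounds shown, and "the series" means these compounds.

Of the compounds shown here, three with a shared core have been measured in a functional assay on NPC-TW01 cells (Homo sapiens) for inhibition, read by MTT assay, with a stated time of 72 h; a higher number here means a weaker inhibitor of growth, a lower number a stronger inhibitor of growth. Compound 1, `COC(=O)c1nc(C)n(-c2ccccc2)n1`, gives > 100000 nM, which is a limit of the assay rather than a number. Compound 2, `COC(=O)c1nc(C)n(-c2ccccc2C(F)(F)F)n1`, gives > 100000 nM, again a limit. The step from compound 1 to compound 2, a step that the two limits leave unreadable from compound 1 to compound 2, is trifluoromethyl in place of hydrogen on an aromatic carbon, and the two limits leave its size unreadable. Compound 3, `CCCCc1nc(C(=O)OC)nn1-c1ccc(F)cc1`, stands with them: in this assay compound 3 gives > 100000 nM, also a limit. the limit of > 100000 nM in this assay, at which 3 of the 3 values shown sit, is where all three values sit. Compound 4, `COC(=O)c1nc(C2CCCCC2)n(-c2ccc(F)cc2)n1`, differs from compound 3 by cyclohexyl in place of butyl on an aromatic carbon. Going by the values given here, no measured step bears on this change; the one recorded step is unreadable. Compound 4 is therefore expected to stay near the limit, with the step estimated as a number no higher from compound 3 to compound 4 (the limit leaves the size open), nothing beyond scatter in either direction. Compound 4 is estimated at 100000 nM, between 30000 nM and 300000 nM.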

Compound 4, concentration for 50% growth inhibition: 30500 nM
For compound 4 the middle estimate is 3.3-fold (0.52 log units) above the measured one; the range from low to high includes it.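

Compound 4 is the only compound shown that gives a number rather than a limit in this assay, while the others remain at that limit: the limit of > 100000 nM in this assay, at which 3 of the 4 values shown sit.

The aromatic carbon between two ring nitrogen atoms is thus the first place shown where a change moves the read-out, with cyclohexyl in place of butyl giving an at least 3.2-fold lower number from compound 3 to compound 4 (0.51 log units; beyond the scatter). As far as these compounds go, compound 3 stands at a limit, so the full size of this step stays open.

Butyl to cyclohexyl changes both the ring and the carbon count, so the compounds shown do not separate the two. From the compounds shown here alone, how a longer chain, a phenyl ring or an amine would read at this place also remains open, as does a carboxylic acid in place of the methoxycarbonyl group.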